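From chloro to methyl in a small sulfonamide series

The source may hold more compounds than are shown below. What is called first, only, known or untested is meant among the compounds shown, and "the series" means these compounds.

For the measured compounds named here, in a functional assay on cells (leukaemia cell line, Homo sapiens) for inhibition, read by sulforhodamine B assay, with a stated time of 48 h (on this read-out higher numbers stand for weaker inhibition of growth and lower numbers for stronger inhibition of growth), compound 1 `O=S(=O)(Nc1ccccc1Cl)c1ccc(-c2cnc(C3CC3)o2)cc1` gives 429 nM and compound 2 `O=S(=O)(Nc1cc(F)cc(Cl)c1)c1ccc(-c2cnc(C3CC3)o2)cc1` gives 1440 nM, so compound 2 holds the higher of only two numbers. Next comes compound 3 `Cc1cc(F)cc(NS(=O)(=O)c2ccc(-c3cnc(C4CC4)o3)cc2)c1`, with methyl in place of chloro on an aromatic carbon, meta to a fluoro group: methyl in place of chloro on an aromatic carbon. Going by the values given here, no measured pair makes this exchange. The nearest evidence is indirect, a modest move beyond the scatter with 3-chloro-5-fluorophenyl in place of 2-chlorophenyl on a sulfonamide nitrogen. With only a 3.4-fold higher number from compound 1 to compound 2 (0.53 log units; beyond the scatter) as a guide, no step beyond the scatter is expected in this assay, and no firm direction can be assigned. The estimated change is a 1.1-fold lower number from compound 2 to compound 3 (0.04 log units; within the scatter). For compound 3 the expected value is 1300 nM, with an estimated range of 500 nM to 3200 nM.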

Compound 3, concentration for 50% growth inhibition: 138 nM
Estimate against measurement, compound 3: 9.4-fold (0.97 log units) above, outside the stated range (below it).
By their numbers in this assay, from the lowest: compound 3; then compound 1; then compound 2.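

Notes on the series: in this assay the exchange of chloro for methyl on an aromatic carbon, meta to a fluoro group, gives a 10-fold lower number from compound 2 to compound 3 (1.02 log units; beyond the scatter) and is a large step for one heavy atom, so this position is far more sensitive than the earlier compounds could show. The 3-fluoro-5-methylphenyl group also gives a 3.1-fold lower number from compound 1 to compound 3 (0.49 log units; beyond the scatter) when it replaces 2-chlorophenyl on the sulfonamide nitrogen, so the loss seen with 3-chloro-5-fluorophenyl does not extend to every group with this substitution pattern. No supporting measurement accounts for the size of this step.

As far as these compounds go, whether methyl is the best group at this position remains open, as an ethyl, methoxy or amine group there would show. The contribution of the fluoro group also remains open, and the compounds shown do not say whether the methyl gain would survive its replacement by hydrogen.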